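Lengthening an Alkoxy Chain: From Compound 3 to Compound 4

The compounds below may be only part of what the source reports. "The series", "measured", "known", "first", "only" and "open" are said of these compounds alone.

Three measured compounds share one core and differ only in a single group on it. Compound 1 `CNc1nc(N)c2nc(O)n(Cc3ccccc3)c2n1` carries a methylamino group; in a functional assay (spleen, spleen) for activation, with Mus musculus as the target (on this read-out higher numbers stand for an effect only at larger amounts of compound and lower numbers for an effect already at smaller amounts), compound 1 gives 1 uM. Compound 2 `CCCCCNc1nc(N)c2nc(O)n(Cc3ccccc3)c2n1` carries a pentylamino group, and in this assay compound 2 gives 0.1 uM. Compound 3 `CCOc1nc(N)c2nc(O)n(Cc3ccccc3)c2n1` carries an ethoxy group, and in this assay compound 3 gives 0.1 uM. The step of a 10-fold lower number from compound 1 to compound 2 (1.00 log units; beyond the scatter) shows that a longer chain on the nitrogen-bound side brought a clearly lower number, the step of a 10-fold lower number from compound 1 to compound 3 (1.00 log units; beyond the scatter) shows ethoxy doing the same against methylamino, and the step of no change at the digits printed from compound 2 to compound 3 (within the scatter) shows no difference. Compound 3 therefore stands level with compound 2, the two together the lowest of the three, and a clear distance from compound 1.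

Compound 4 `CCCCCOc1nc(N)c2nc(O)n(Cc3ccccc3)c2n1` repeats the chain lengthening, now on the oxygen-bound side: propyl in place of hydrogen on a saturated chain carbon, two bonds along the chain from an oxygen on an aromatic ring. For the measured compounds named here, the one measured step that bears on such lengthening is a 10-fold lower number from compound 1 to compound 2 (1.00 log units; beyond the scatter), modest in size and downward. Since compound 3 is already level with compound 2, a smaller downward move is expected in this assay. Compound 4 is expected to give 0.03 uM, with a likely range from 0.005 uM to 0.3 uM. The step this estimate implies is expected to be a 3.3-fold lower number from compound 3 to compound 4 (0.52 log units; beyond the scatter).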

Compound 4, minimum effective concentration: 0.01 uM
Compound 4: the middle estimate sits 3.0-fold (0.48 log units) above what was measured; measured number inside the range.
By their numbers in this assay, from the lowest: compound 4; then compounds 2 and 3 (each within the scatter of the next); then compound 1.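

In this assay, for the compounds shown here, lengthening ethoxy to pentyloxy gives a 10-fold lower number from compound 3 to compound 4 (1.00 log units; beyond the scatter) and so shows that chain length matters on the oxygen-bound side too, which the earlier compounds showed only on the nitrogen-bound side. With the pentyl chain held constant, pentyloxy in place of pentylamino gives a 10-fold lower number from compound 2 to compound 4 (1.00 log units; beyond the scatter), so the linking atom also matters here, a difference that the level pair of compound 2 and compound 3 could not reveal, as those two differ in both chain and linking atom. Pentyloxy in place of methylamino gives a 100-fold lower number from compound 1 to compound 4 (2.00 log units; beyond the scatter), the widest gap among these compounds, and compound 4 now holds the lowest number of the four, with its steps to all the others beyond the scatter.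

On these data alone, it remains open whether a longer chain such as heptyloxy would lower the number further or whether the trend stops at pentyloxy, and how a carboxylic acid at this same place on the core would read. No measurement on hand explains why the oxygen-linked pentyl chain gives the lowest number.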